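This account rests on a few compounds, and the source may have more. Where it says the series, first, only, none or still open, it means among the compounds named here.

Measured compounds:

Compound 1, `COc1cccc(NC(=O)NC2CC(C)(C)Oc3ccc(Cl)cc32)c1`, gives > 10000 nM in a functional assay (aorta) with Rattus norvegicus as the target (a lower number here means that less compound is needed, a higher number that more compound is needed for the effect), which is a limit of the assay and not a number.
Compound 2, `COc1cccc(NC(=O)NC2CC(C)(C)Oc3ccc(Br)cc32)c1`, gives > 10000 nM in this assay; this too is a limit.
Compound 3, `Cc1ccc(NC(=O)NC2CC(C)(C)Oc3ccc(Cl)cc32)cc1`, gives > 30000 nM in this assay; again a limit.

All three compounds share a core and differ in two places. From compound 1 to compound 2 the change is bromo in place of chloro on an aromatic carbon. The step that the two limits leave unreadable from compound 1 to compound 2 cannot be sized, since both values are limits, as the limit of > 10000 nM in this assay, at which 2 of the 3 values shown sit, shows. From compound 1 to compound 3 the cores differ by 4-methylphenyl in place of 3-methoxyphenyl on an amide-type nitrogen, and the step that the two limits leave unreadable from compound 1 to compound 3 is also unreadable, since compound 3 sits at the limit of > 30000 nM in this assay, at which 1 of the 3 values shown sits, while compound 1 sits at the limit of > 10000 nM in this assay, at which 2 of the 3 values shown sit.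

Compound 4, `Cc1ccc(NC(=O)NC2CC(C)(C)Oc3ccc(Br)cc32)cc1`, is not yet measured. It differs from compound 3 by bromo in place of chloro on an aromatic carbon, the same change as that from compound 1 to compound 2, in the same place. The step from compound 3 to compound 4 in this assay is expected to be a number no higher from compound 3 to compound 4 (the limit leaves the size open), which rests on the unreadable step that the two limits leave unreadable from compound 1 to compound 2 and on the fact that every measured value here is a limit, as the limit of > 10000 nM in this assay, at which 2 of the 3 values shown sit, and the limit of > 30000 nM in this assay, at which 1 of the 3 values shown sits, record. Compound 4 is expected to give about 30000 nM, within a range from 10000 nM to 100000 nM, most likely reported as a limit again.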

Compound 4, half-maximal effective concentration: > 30000 nM
Compound 4: only a limit was reported (the forecaster's own chance of this, stated with the estimate: 85%); the middle value sits exactly at the limit.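

The steps from compound 3 to compound 4 and from compound 2 to compound 4 cannot be sized: the values of all these compounds in this assay are limits of the assay and not numbers. The compounds shown leave open whether bromo in place of chloro, or 4-methylphenyl in place of 3-methoxyphenyl, changes the concentration needed, and what concentration any of these compounds would need for the effect.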